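Fluoro for methoxy: from compound 2 to compound 3

This account rests on a few compounds, and the source may have more. Where it says the series, first, only, none or still open, it means among the compounds named here.

Compound 1 `CC[C@H](C)[C@H](N)CN(C(=O)[C@@H]1C[C@H]1c1ccc(OC)cc1)c1ccc(-c2ccccc2)cc1` sits at a limit of the assay, > 25000 nM. Compound 2 `CC[C@H](C)[C@H](N)CN(C(=O)[C@@H]1C[C@H]1c1cccc(OC)c1)c1ccc(-c2ccccc2)cc1` gives 3000 nM.

In a functional assay for agonist activity at G protein-coupled receptor 88 (Homo sapiens), read by HTRF and cAMP accumulation (on this read-out higher numbers stand for an effect only at larger amounts of compound and lower numbers for an effect already at smaller amounts), compound 2 holds the only number shown; the other value is a limit, (the limit of > 25000 nM in this assay, at which 1 of the 2 values shown sits). Going by the values given here, the one measured step, an at least 8.3-fold lower number from compound 1 to compound 2 (0.92 log units; beyond the scatter), moved the methoxy rather than replaced it, so it bears only indirectly on the new change. Compound 3 `CC[C@H](C)[C@H](N)CN(C(=O)[C@@H]1C[C@H]1c1cccc(F)c1)c1ccc(-c2ccccc2)cc1` differs from compound 2 by fluoro in place of methoxy on an aromatic carbon. Among the compounds with values here, with no direct precedent, a modest loss is expected, a 2.0-fold higher number from compound 2 to compound 3 (0.30 log units; within the scatter). Compound 3 is estimated at 6000 nM, within 1500 nM to 25000 nM.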

Compound 3, half-maximal effective concentration: 560 nM
Beside the measured number, compound 3's estimate is 11-fold (1.03 log units) above it, and the stated range ends above it.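

In this assay, fluoro in place of methoxy gives a 5.4-fold lower number from compound 2 to compound 3 (0.73 log units; beyond the scatter), so the methoxy of 3-methoxyphenyl is not required for activity, and a group with no counted hydrogen-bond acceptor is tolerated on this aromatic carbon. Against 4-methoxyphenyl, 3-fluorophenyl gives an at least 44-fold lower number from compound 1 to compound 3 (1.64 log units; beyond the scatter), a step that rests on a limit: the limit of > 25000 nM in this assay, at which 1 of the 3 values shown sits.

That step changes both the group and its place, so their shares stay unseparated. Going by these compounds, how chloro, nitrile or hydroxy would read on this aromatic carbon remains open.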